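The compounds below may be only part of what the source reports. "The series", "measured", "known", "first", "only" and "open" are said of these compounds alone.

Measured compounds in a functional assay on the whole organism (strain Swiss) with Mus musculus as the target, in the maximal electroshock model, with a stated time of 0.5 h, at a dose of 300 mg/kg by the intraperitoneal route; a lower number here means a weaker effect, a higher number a stronger effect of the compound at the dose given:
compound 1 `COc1cccc(N2CCN(C(=O)C(C)N3C(=O)CCC3=O)CC2)c1`: 50%
compound 2 `CC(C(=O)N1CCN(c2ccccc2)CC1)N1C(=O)CCC1=O`: 50%
compound 3 `CCC(C(=O)N1CCN(c2cccc(OC)c2)CC1)N1C(=O)CCC1=O`: 0%

Compound 3 stands lowest of the three numbers in this assay; the nearest is compound 1, and the step of a number 50 percentage points lower from compound 1 to compound 3 (beyond the scatter) is beyond the scatter, as is the gap to compound 2, whose value is the same as that of compound 1.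

Compound 4 `CCC(C(=O)N1CCN(c2ccccc2F)CC1)N1C(=O)CCC1=O` differs from compound 3 only at the aryl group: 2-fluorophenyl in place of 3-methoxyphenyl on an amine nitrogen in a ring. The ethyl-bearing chain carbon of compound 3 is kept.

Of the measured steps, only the aryl change no change at the digits printed from compound 1 to compound 2 (within the scatter) bears on this: removing the methoxy from the aromatic ring left the number unchanged within the scatter. The step of a number 50 percentage points lower from compound 1 to compound 3 (beyond the scatter) concerns the chain and is not touched here. For the measured compounds named here, the fluorine has no measured counterpart, so the aryl comparison is the only guide; no change beyond the scatter is therefore expected.

Compound 4 is expected to give about 10%, with a range of 0% to 35%. The expected step is thus a number 10 percentage points higher from compound 3 to compound 4 (within the scatter), within the scatter.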

Compound 4, a percentage reported as activity, at one dose (the size of the read-out at that dose, not a potency): 100%
The estimate for compound 4 lay 90 percentage points below the measured number; the whole stated range lies below it.
By their numbers in this assay, from the lowest: compound 3; then compounds 1 and 2 (each within the scatter of the next); then compound 4.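

In this assay, for the compounds shown here, the aryl group on the amine nitrogen in a ring can carry a large effect: 2-fluorophenyl in place of 3-methoxyphenyl gives a number 100 percentage points higher from compound 3 to compound 4 (beyond the scatter) and so differs from the only earlier aryl step, which was no change at the digits printed from compound 1 to compound 2 (within the scatter) in a compound with the shorter chain. The ethyl-bearing chain carbon is kept across the new step, so the earlier step of a number 50 percentage points lower from compound 1 to compound 3 (beyond the scatter) cannot be read as a loss that the chain imposes whatever the aryl group. Nothing at hand accounts for the size of the new step.

Going by these compounds, whether a chlorine or a methyl group in place of the fluorine would hold the high number remains open. Also open, on these data alone, are how a longer chain on the chain carbon would fare with 2-fluorophenyl and whether the effect of compound 4 persists at lower doses.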